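The source may report more compounds than this note shows. Statements on the series, on what has been measured and on what is new or still open speak of the compounds shown alone.

Compound 1 `CC(C)c1[nH]cnc1/C=c1\[nH]c(=O)/c(=C/c2cccc(Oc3ccc(F)cc3)c2)[nH]c1=O` gives 8.8 nM in a functional assay on NCI-H460 cells (Homo sapiens) for cytotoxicity, read by MTT assay, with a stated time of 72 h (on this read-out higher numbers stand for weaker inhibition and lower numbers for stronger inhibition), and has the lowest number of the three measured compounds, both neighbours lying beyond the scatter. Compound 2 `O=c1[nH]/c(=C\c2c[nH]cn2)c(=O)[nH]/c1=C\c1cccc(Oc2ccc(F)cc2)c1` gives 479 nM and compound 3 `O=c1[nH]/c(=C\c2cccc(Oc3ccc(F)cc3)c2)c(=O)[nH]/c1=C\c1ccccc1` gives 389 nM; the two differ by a 1.2-fold lower number from compound 2 to compound 3 (0.09 log units; within the scatter). The change to compound 4 `O=c1[nH]/c(=C\c2ccc(Br)o2)c(=O)[nH]/c1=C\c1cccc(Oc2ccc(F)cc2)c1` is 5-bromofuran-2-yl in place of 5-isopropyl-1H-imidazol-4-yl on a double-bonded chain carbon bound to an aromatic carbon. Among the compounds with values here, two measured steps bear on it, each touching the same group: a 54-fold higher number from compound 1 to compound 2 (1.74 log units; beyond the scatter) and a 44-fold higher number from compound 1 to compound 3 (1.65 log units; beyond the scatter). Both alterations of the 5-isopropyl-1H-imidazol-4-yl group cost heavily, and the 5-bromofuran-2-yl group is again neither the imidazole nor bears the isopropyl, so a large rise in the number is expected for compound 4, about a 40-fold higher number from compound 1 to compound 4 (1.60 log units; beyond the scatter). Compound 4 is therefore estimated at 350 nM, with a range of 80 nM to 1500 nM.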

Compound 4, half-maximal inhibitory concentration: 361 nM
For compound 4 the middle estimate is 1.0-fold (0.01 log units) below the measured one, within the range that was stated.
By their numbers in this assay, from the lowest: compound 1; then compounds 4, 3 and 2 (each within the scatter of the next).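

On a double-bonded chain carbon bound to an aromatic carbon, a third replacement of 5-isopropyl-1H-imidazol-4-yl, now without a ring nitrogen, also loses the low number, with a 41-fold higher number from compound 1 to compound 4 (1.61 log units; beyond the scatter). In this assay, 5-bromofuran-2-yl cannot be separated from the other replacements, with a 1.1-fold lower number from compound 3 to compound 4 (0.03 log units; within the scatter) and a 1.3-fold lower number from compound 2 to compound 4 (0.12 log units; within the scatter), so 1H-imidazol-4-yl, phenyl and 5-bromofuran-2-yl all sit at one level. No measurement offered here accounts for this. Open, going by these compounds, is whether an ethyl or a tert-butyl in place of the isopropyl of compound 1 keeps its number, and whether an isopropyl on the furan of compound 4 restores it.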